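Dropping the Methyl from Compound 3

This account rests on a few compounds, and the source may have more. Where it says the series, first, only, none or still open, it means among the compounds named here.

Compound 1 `CC1=NNC(=O)C1C(c1c(-c2ccccc2)[nH]c2ccccc12)c1c(-c2ccccc2)[nH]c2ccc(C)cc12`: in a functional assay on A549 cells (Homo sapiens) for cytotoxicity, read by MTT assay (a higher number here means a weaker inhibitor, a lower number a stronger inhibitor), compound 1 gives 22100 nM.
Compound 2 `CC1=NNC(=O)C1C(c1c(-c2ccccc2)[nH]c2ccccc12)c1c(-c2ccccc2)[nH]c2ccc(Cl)cc12`: in this assay compound 2 gives 31300 nM.
Compound 3 `CC1=NNC(=O)C1C(c1c[nH]c2ccccc12)c1c(-c2ccccc2)[nH]c2ccc(C)cc12`: in this assay compound 3 gives 1300 nM.

Compound 3 stands lowest of the three numbers in this assay; compound 1 is its nearest neighbour, with compound 2 further off. Compound 4 `CC1=NNC(=O)C1C(c1c[nH]c2ccccc12)c1c(-c2ccccc2)[nH]c2ccccc12` differs from compound 3 by hydrogen in place of methyl on an aromatic carbon. The step that bears on this change is a 1.4-fold higher number from compound 1 to compound 2 (0.15 log units; within the scatter), where chloro replaced methyl on an aromatic carbon and the numbers stayed within the scatter. The large step of a 17-fold lower number from compound 1 to compound 3 (1.23 log units; beyond the scatter) concerns the phenyl and says nothing about the methyl. Among the compounds with values here, only one exchange at this place has been seen, so the evidence is thin, but it points to no effect, and the expected step is a 1.1-fold higher number from compound 3 to compound 4 (0.03 log units; within the scatter). Compound 4 is therefore estimated at 1400 nM in this assay, with a range from 500 nM to 4000 nM.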

Compound 4, half-maximal inhibitory concentration: 5500 nM
For compound 4 the middle estimate is 3.9-fold (0.59 log units) below the measured one; measured number outside the range, above it.
By their numbers in this assay, from the lowest: compound 3; then compound 4; then compounds 1 and 2 (each within the scatter of the next).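

Removing the methyl matters in this assay: the step is a 4.2-fold higher number from compound 3 to compound 4 (0.63 log units; beyond the scatter), so this place on the six-membered aromatic ring is not indifferent to what it carries, at least in the pair without the second phenyl. Within the data shown here, the only earlier exchange here, a 1.4-fold higher number from compound 1 to compound 2 (0.15 log units; within the scatter), was made in a pair that carries that phenyl and replaced methyl with chloro, so the flat result there does not extend to hydrogen in place of methyl in compounds 3 and 4. Nothing measured on these compounds speaks to the reason for the step.

The compounds shown leave open whether hydrogen in place of methyl would give a similar step with the second phenyl present, and how chloro would read in the pair without it. As far as these compounds go, how a methoxy group, an amine or a longer chain would read at this place also remains open.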